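Ramos cell inhibition notes: compounds 2, 3 and 4

A few compounds are considered here, and "the series" means these few. Any claim that something is new, unique, unknown or untested is made for them only; others in the source may bear on it.

Measured compounds in a functional assay on Ramos cells (Homo sapiens) for inhibition, read by MTT assay, with a stated time of 48 h; on this read-out lower numbers stand for stronger inhibition and higher numbers for weaker inhibition:
compound 1 `C=CC(=O)Nc1cccc(Nc2ncnc3ccc(-c4ccc(F)nc4)cc23)c1`: "not determined" (no result reported)
compound 2 `C=CC(=O)Nc1cccc(Nc2ncnc3ccc(-c4cnc5ccccc5c4)cc23)c1`: > 50000 nM
compound 3 `CC#CC(=O)Nc1cccc(Nc2ncnc3ccc(-c4cnc5ccccc5c4)cc23)c1`: > 50000 nM

Compound 2 stands only at a limit of this assay: > 50000 nM is a limit and not a number. Compound 3 likewise reaches only a limit, > 50000 nM. Compound 1 carries no result at all. For the measured compounds named here, the single measured step, a step that the two limits leave unreadable from compound 2 to compound 3, is therefore unreadable; two of the three entries sit at the limit of > 50000 nM in this assay, at which 2 of the 3 values shown sit, and the third is empty, so compound 2 cannot be ranked against any other compound in this assay.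

Compound 4 `C=CC(=O)Nc1cc(Nc2ncnc3ccc(-c4cnc5ccccc5c4)cc23)ccc1C` differs from compound 2 by methyl in place of hydrogen on an aromatic carbon. Going by the values given here, no measured step touches this part of the molecule, and the one step that exists, from compound 2 to compound 3, gives no readable size. Nothing in the numbers sets a direction for the change. Compound 4 is expected to remain at or close to the limit, with an estimated step that the limit leaves unreadable from compound 2 to compound 4. The estimate for compound 4 in this assay is 60000 nM, with a range from 15000 nM to 250000 nM, most likely reported as a limit only.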

Compound 4, half-maximal inhibitory concentration: 5400 nM
Beside the measured number, compound 4's estimate is 11-fold (1.05 log units) above it; the measured number lies below the stated range.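

In this assay, methyl in place of hydrogen on an aromatic carbon, ortho to a (vinylcarbonyl)amino group and para to a large group, gives an at least 9.2-fold lower number from compound 2 to compound 4 (0.96 log units; beyond the scatter). This ring position therefore responds to a single added carbon, whereas the only earlier change, at the carbonyl carbon, produced a step that cannot be read, and compound 4 is the one compound shown that leaves the limit behind and carries a number: the limit of > 50000 nM in this assay, at which 2 of the 4 values shown sit. On these data alone, compound 2 still stands at a limit, so the step is bounded on one side only, and its full size remains unknown.

As far as these compounds go, whether ethyl, methoxy or chlorine at the same place would match, exceed or lose the gain seen with methyl stays open, as does whether the methyl group would act the same way on another ring carbon. From the compounds shown here alone, it is also open whether the same methyl group would lift compound 3, with its prop-1-yn-1-yl group on the carbonyl carbon, off the limit, and the numbers give no reason for the step itself.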